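Shortening the hydroxamate chain on a shared core

The source may report more compounds than this note shows. Statements on the series, on what has been measured and on what is new or still open speak of the compounds shown alone.

Compound 1 `Nc1ncnc2c1c(-c1cnc3[nH]ccc3c1)nn2CCCC(=O)NO` in a functional assay on MCF7 cells (Homo sapiens) for inhibition, read by MTT assay, with a stated time of 72 h (a lower number here means a stronger inhibitor, a higher number a weaker inhibitor), gives > 150000 nM, which is a limit of the assay and not a number.
Compound 2 `Nc1nc2cc(-c3nn(CCCCCCCCCC(=O)NO)c4ncnc(N)c34)ccc2o1` in this assay gives > 50000 nM, again a limit.
Compound 3 `Nc1ncnc2c1c(-c1cnc3[nH]ccc3c1)nn2CC(=O)NO` in this assay gives > 150000 nM, also a limit.

Compound 2 therefore stands only at a limit in this assay, and the two other values shown are limits as well, so no number places it against them. Compound 4 `Nc1nc2cc(-c3nn(CCCCCCC(=O)NO)c4ncnc(N)c34)ccc2o1` differs from compound 2 by hydroxycarbamoyl in place of 3-(hydroxycarbamoyl)propyl on a saturated chain carbon, six bonds along the chain from an aromatic nitrogen. Among the compounds with values here, the one measured step of related kind, a step that the two limits leave unreadable from compound 1 to compound 3, is a shortening of the same sort, yet both of its ends sit at the limit of > 150000 nM in this assay, at which 2 of the 3 values shown sit, so its size cannot be read. What the data show is that chain length has not lifted any compound off a limit: the two shorter chains sit at the limit of > 150000 nM in this assay, at which 2 of the 3 values shown sit, and the longest at the limit of > 50000 nM in this assay, at which 1 of the 3 values shown sits. For compound 4 the expectation is therefore no readable step beyond the scatter, with the step that the limit leaves unreadable from compound 2 to compound 4 expected to remain unreadable in this assay. Compound 4 is estimated at 100000 nM, in a range from 30000 nM to 300000 nM, most likely reported again as a limit.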

Compound 4, half-maximal inhibitory concentration: 11900 nM
Beside the measured number, compound 4's estimate is 8.4-fold (0.92 log units) above it; the whole stated range lies above it.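

Shortening the chain, with hydroxycarbamoyl in place of 3-(hydroxycarbamoyl)propyl on a saturated chain carbon, six bonds along the chain from an aromatic nitrogen, gives in this assay an at least 4.2-fold lower number from compound 2 to compound 4 (0.62 log units; beyond the scatter), the first step in this set that can be read. Compound 2 gives > 50000 nM, which is a limit, so the real size of the step may be larger than the printed one. The other shortening, on a different core, from compound 1 to compound 3, still cannot be read, as both of its ends sit at one limit: the limit of > 150000 nM in this assay, at which 2 of the 4 values shown sit.

With only these two chains shown on this core, it stays open whether a 5-(hydroxycarbamoyl)pentyl or a (hydroxycarbamoyl)methyl chain would give a number or a limit in this assay. From the compounds shown here alone, it is also open whether the hydroxycarbamoyl end itself is needed for the value of compound 4, which a carboxylic acid or a primary amide at the end of the same chain would test.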